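Swapping Nitro for Chloro on a Vero Cell Cytotoxicity Read-out

This account rests on a few compounds, and the source may have more. Where it says the series, first, only, none or still open, it means among the compounds named here.

Of the compounds shown here, two sharing one core have been tested in an ADME assay on Vero cells (Chlorocebus sabaeus) for cytotoxicity, read by neutral red uptake, tested at 3150 ug/mL; on this read-out higher numbers stand for a weaker effect at the one concentration tested and lower numbers for a stronger effect. Compound 1 `O=C1CSC(c2cccc(Cl)c2)N1CCN1CCCCC1` carries a chloro group on its aromatic ring and in this assay gives 15%. Compound 2 `O=C1CSC(c2ccccc2[N+](=O)[O-])N1CCN1CCCCC1` carries a nitro group instead and gives 30%, the higher of the two numbers, standing a step above compound 1 that is beyond the usual scatter of repeated measurements; on this read-out the higher number means the weaker effect on the cells.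

Compound 3 `O=C1CSC(c2ccccc2Cl)N1CCN1CCCCC1` has not yet been measured. It differs from compound 2 in one place: chloro in place of nitro on an aromatic carbon. Going by the values given here, no measured pair shows this exact change, so the only guide is that compound 1, which also carries chloro rather than nitro, sits lower in this assay than compound 2. On that basis the expected step of a number 10 percentage points lower from compound 2 to compound 3 (within the scatter) is a fall in the number, probably beyond the scatter, meaning a somewhat stronger effect. Compound 3 is expected to give about 20%, estimated to fall between 5% and 40%.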

Compound 3, a percentage reported as activity, at one concentration (the size of the read-out at that concentration, not a potency): 22%
The estimate for compound 3 lay 2 percentage points below the measured number, and the stated range covers the measured number.
By their numbers in this assay, from the lowest: compounds 1, 3 and 2 (each within the scatter of the next, the first and the last beyond it).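

Within this assay, chloro in place of nitro on an aromatic carbon, ortho to a large group, gives a number 8 percentage points lower from compound 2 to compound 3 (within the scatter) and so cannot be told apart from the ordinary spread of repeated measurements. Exchanging the larger nitro group, with its oxygens, for a single chlorine therefore leaves no readable mark at this position. The new compound also provides a second single-change comparison, 2-chlorophenyl in place of 3-chlorophenyl on a saturated ring carbon, and a number 7 percentage points higher from compound 1 to compound 3 (within the scatter) is again too small to read as a real difference, while nothing available here offers an explanation for either result.

As far as these compounds go, whether an amine, a methoxy group or a carboxylic acid at this position would move the number beyond the scatter remains open. Also open, from the compounds shown here alone, is how these groups would behave elsewhere on the aromatic ring, and whether a longer chain on the shared core would change the reading.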